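Swapping the aryl group on the ring nitrogen of compound 3

The source may hold more compounds than are shown below. What is called first, only, known or untested is meant among the compounds shown, and "the series" means these compounds.

Compound 3 `Cn1ccc2c(Oc3ccc(NC(=O)c4cc5cccnc5n(-c5ccc(F)cc5)c4=O)cc3)ccnc21` was tested in a functional assay on U-87MG ATCC cells for antiproliferative activity against U-87 MG (Homo sapiens), read by MTT assay, with a stated time of 72 h (a lower number here means a stronger inhibitor, a higher number a weaker inhibitor), and gives 2120 nM, the second highest of the three numbers shown. Compound 1 `O=C(Nc1ccc(Oc2ccnc3[nH]ccc23)cc1)c1cc2cccnc2n(-c2ccc(F)cc2)c1=O` gives 1360 nM, and a 1.6-fold higher number from compound 1 to compound 3 (0.19 log units; within the scatter) lies within the scatter. Compound 2 `O=C(Nc1ccc(Oc2ccnc3[nH]ccc23)c(F)c1)c1cc2cccnc2n(-c2ccc(F)c(Cl)c2)c1=O` gives 5230 nM, the highest number shown, but it differs from compound 1 in two places at once, so no single step can be read from it. Compound 4 `Cn1ccc2c(Oc3ccc(NC(=O)c4cc5cccnc5n(-c5ccc(C(F)(F)F)cc5Cl)c4=O)cc3)ccnc21` carries 2-chloro-4-(trifluoromethyl)phenyl in place of 4-fluorophenyl on an aromatic nitrogen. Going by the values given here, no measured step covers this exchange, so the data give no direct guide, and only a loose, weakening trend can be guessed. The expected step is a 1.9-fold higher number from compound 3 to compound 4 (0.28 log units; within the scatter). Compound 4 is therefore estimated at 4000 nM, with a range from 1200 nM to 14000 nM.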

Compound 4, half-maximal inhibitory concentration: 12600 nM
The estimate for compound 4 lay 3.2-fold (0.50 log units) below the measured number; the range from low to high includes it.
By their numbers in this assay, from the lowest: compounds 1 and 3 (each within the scatter of the next); then compound 2; then compound 4.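

In this assay, going by these compounds alone, the group on the aromatic nitrogen can clearly move the number: 2-chloro-4-(trifluoromethyl)phenyl in place of 4-fluorophenyl gives a 5.9-fold higher number from compound 3 to compound 4 (0.77 log units; beyond the scatter), while the single methyl step from before stayed within the scatter. The entering group brings the chloro and the trifluoromethyl together, so the step cannot be divided between them. Nothing available explains this rise in the number. Still open, going by these compounds, is whether the chloro or the trifluoromethyl alone would give such a step. Also open, on these data alone, is how a plain phenyl or a short alkyl chain on this nitrogen would read.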